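A few compounds are considered here, and "the series" means these few. Any claim that something is new, unique, unknown or untested is made for them only; others in the source may bear on it.

Four compounds share one core; the measured three are compound 1 `CCCCCCCCOP(=O)(O)OCCSC(=S)N1CCCCC1`, compound 2 `CCCCCCCCCCOP(=O)(O)OCCSC(=S)N1CCN(C)CC1` and compound 3 `CCCCCCCCOP(=O)(O)OCCSC(=S)N1CCN(C)CC1`. In a functional assay on PC-3 cells (Homo sapiens) for inhibition, read by MTT assay, with stated times of 18 h and 4 h (on this read-out higher numbers stand for weaker inhibition and lower numbers for stronger inhibition), compound 2 gives 80000 nM. For compound 3 the reading in this assay is only a limit of the assay, > 100000 nM. For compound 1 the reading is likewise a limit, > 100000 nM. Compound 2 differs from compound 3 by ethyl in place of hydrogen on a saturated chain carbon, eight bonds along the chain from an oxygen on an unsaturated carbon, and the step of an at least 1.2-fold higher number from compound 2 to compound 3 (0.09 log units; that floor lies within the scatter) follows. Compound 1 differs from compound 3 by piperidin-1-yl in place of 4-methylpiperazin-1-yl on a thiocarbonyl carbon, giving a step that the two limits leave unreadable from compound 3 to compound 1, a step that cannot be sized because of the limit of > 100000 nM in this assay, at which 2 of the 3 values shown sit. The unmeasured compound 4 `CCCCCCCCCCOP(=O)(O)OCCSC(=S)N1CCCCC1` differs from compound 2 by piperidin-1-yl in place of 4-methylpiperazin-1-yl on a thiocarbonyl carbon, the same change as that from compound 3 to compound 1. Since that earlier step is unreadable, the expectation for compound 4 rests on compound 2 staying as the nearest measured number, 80000 nM, with a step of a 1.3-fold higher number from compound 2 to compound 4 (0.10 log units; within the scatter) expected. Compound 4 is therefore estimated at 100000 nM in this assay, between 40000 nM and 300000 nM, with a fair chance that only a limit is reported.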

Compound 4, half-maximal inhibitory concentration: 62500 nM
The estimate for compound 4 lay 1.6-fold (0.20 log units) above the measured number, within the range that was stated.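

In this assay, piperidin-1-yl in place of 4-methylpiperazin-1-yl on a thiocarbonyl carbon gives a 1.3-fold lower number from compound 2 to compound 4 (0.11 log units; within the scatter). Ethyl in place of hydrogen on a saturated chain carbon, eight bonds along the chain from an oxygen on an unsaturated carbon, gives an at least 1.6-fold lower number from compound 1 to compound 4 (0.20 log units; that floor lies within the scatter), and the two cores can be set side by side for this change: the same change on two cores in this assay, an at least 1.2-fold higher number (0.09 log units; that floor lies within the scatter) from compound 2 to compound 3 and an at least 1.6-fold higher number (0.20 log units; that floor lies within the scatter) from compound 4 to compound 1; the limit leaves it open whether they differ. The pair therefore fits a change that carries from one core to the other, but it does not show that the step keeps its size, or even that it exceeds the scatter on either core, because only limits stand at the shorter chain: the limit of > 100000 nM in this assay, at which 2 of the 4 values shown sit.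

The compounds shown leave open how the read-out would move with a longer chain than that of compound 2 and compound 4. They also leave open whether morpholin-4-yl on the thiocarbonyl carbon would read any differently from the two rings shown here.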